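A few compounds are considered here, and "the series" means these few. Any claim that something is new, unique, unknown or untested is made for them only; others in the source may bear on it.

Measured so far in a functional assay on TSGH cells (Homo sapiens) for inhibition, with a stated time of 72 h; a lower number here means a stronger inhibitor, a higher number a weaker inhibitor:

- compound 1 `COc1cc(C(=O)c2ccc3cc[nH]c3c2)cc(OC)c1OC`: 430 nM
- compound 2 `CCn1ccc2cc(C(=O)c3cc(OC)c(OC)c(OC)c3)ccc21`: 41 nM

Of these two numbers, compound 2 has the lower one, 41 nM, which makes it the stronger inhibitor of the pair. Compound 1, at 430 nM, lies above it by a gap beyond the usual scatter.

The next compound, compound 3 `COc1cc(C(=O)c2ccc3c(ccn3CCC(=O)O)c2)cc(OC)c1OC`, has not yet been measured in this assay. It differs from compound 2 by carboxy in place of hydrogen on a saturated chain carbon, two bonds along the chain from an aromatic nitrogen, so that ethyl becomes 2-carboxyethyl (carboxy in place of hydrogen on a saturated chain carbon, two bonds along the chain from an aromatic nitrogen). Going by the values given here, no measured pair isolates this change, and no measured compound carries a carboxy group, so any expectation here is uncertain. A sizeable rise beyond the scatter, meaning a weaker inhibitor, is expected for the step of a 22-fold higher number from compound 2 to compound 3 (1.34 log units; beyond the scatter). The estimate for compound 3 is 900 nM, with an expected range of 120 nM to 7000 nM.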

Compound 3, half-maximal inhibitory concentration: > 10000 nM
Compound 3 ended at the assay's limit; the forecaster's own chance of this, stated with the estimate: 15%; at least 11-fold (1.04 log units) between middle value and limit.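

Going by these compounds alone, the carboxy group is the first change at this chain carbon, and it shows that the position is highly sensitive: in this assay, turning ethyl into 2-carboxyethyl gives an at least 240-fold higher number from compound 2 to compound 3 (2.38 log units; beyond the scatter), a large step beyond the scatter. Going by these compounds, the value of compound 3 is a limit and not a number, so the true size of the step remains unknown: the limit of > 10000 nM in this assay, at which 1 of the 3 values shown sits. Even so, this single change is enough to take compound 3 out of the range that the assay reports.

One compound cannot show whether the carboxy group itself matters or whether any added group at this chain carbon would have the same effect. The compounds shown also leave open how a methyl ester, an amide, an amine or a longer chain would fare here.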